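From methoxycarbonyl to methoxymethyl on compound 2

A few compounds are considered here, and "the series" means these few. Any claim that something is new, unique, unknown or untested is made for them only; others in the source may bear on it.

Of the compounds shown here, three on a closely related core have been read in a functional assay on A549 cells (Homo sapiens) for cytotoxicity, read by MTT assay, with a stated time of 72 h; on this read-out lower numbers stand for an effect already at smaller amounts and higher numbers for an effect only at larger amounts of compound. Compound 1 (`CCc1cccc2c(O)c(-c3occ(C)c3C(=O)O)ccc12`) gives 10.6 ug/mL. Compound 2 (`CCc1cccc2c(OC)c(-c3occ(C)c3C(=O)OC)ccc12`) gives 1.5 ug/mL, the lower of the two numbers, and its gap to compound 1 lies beyond the scatter. Compound 3 (`CCOc1c(-c2occ(C)c2CO)ccc2c(CC)cccc12`) reads > 10 ug/mL, which is a limit and not a number.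

Compound 4 (`CCc1cccc2c(OC)c(-c3occ(C)c3COC)ccc12`) is reached from compound 2 by a single change: methoxymethyl in place of methoxycarbonyl on an aromatic carbon. For the measured compounds named here, no measured pair isolates this change, as compound 1 and compound 3 each differ from compound 2 in more than one place. The expectation in this assay is therefore a modest step to a higher number, probably just beyond the scatter. Going by the values given here, its only support is that compound 1, which lacks methoxycarbonyl, stands at 10.6 ug/mL. The expected move is a 2.7-fold higher number from compound 2 to compound 4 (0.43 log units; beyond the scatter). For compound 4 the estimated value is 4 ug/mL, with an expected range of 1.2 ug/mL to 13 ug/mL.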

Compound 4, concentration for half-maximal effect: > 10 ug/mL
Compound 4 gave a limit, no number; the forecaster's own chance of this, stated with the estimate: 20%; middle value at least 2.5-fold (0.39 log units) away from the limit.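

In this assay the series now has its first reading of a single change at this position, the aromatic carbon of the five-membered aromatic ring with 1 oxygen: methoxymethyl in place of methoxycarbonyl gives an at least 6.6-fold higher number from compound 2 to compound 4 (0.82 log units; beyond the scatter). Compound 4 reads > 10 ug/mL, which is a limit and not a number. The position is therefore not indifferent to this exchange, since the step lies beyond the scatter, but its full size cannot be read, and the step rests on a value at the limit shared within the series: the limit of > 10 ug/mL in this assay, at which 2 of the 4 values shown sit.

The pair does not separate the carbonyl from the rest of the methoxycarbonyl group, and an amide or a nitrile on the same carbon of compound 2 would be the next readings to set beside it, as would a longer ester such as ethoxycarbonyl. Compound 1 and compound 3 each differ from compound 2 in more than one place, so the carboxylic acid of compound 1 and the hydroxymethyl of compound 3 cannot be read as single changes at this position.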